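Amide nitrogen aryl variation: chloro to methoxy

The source may report more compounds than this note shows. Statements on the series, on what has been measured and on what is new or still open speak of the compounds shown alone.

Measured compounds:
compound 1 `Cn1cc(C2=C(c3n[nH]c4ncccc34)C(=O)N(c3cccc4ccccc34)C2=O)c2ccccc21`: > 100000 nM
compound 2 `Cn1cc(C2=C(c3nn(CCCN4CCCCC4)c4ncccc34)C(=O)N(c3ccccn3)C2=O)c2ccccc21`: 7300 nM
compound 3 `Cn1cc(C2=C(c3nn(CCCN4CCCCC4)c4ncccc34)C(=O)N(c3ccc(Cl)cc3)C2=O)c2ccccc21`: > 100000 nM

In a functional assay on ECa-109 cells (Homo sapiens) for antiproliferative activity, read by MTT assay, with a stated time of 48 h (a higher number here means a weaker inhibitor, a lower number a stronger inhibitor), compound 2 gives 7300 nM. The value of compound 3 is a limit of the assay, > 100000 nM. Compound 1 likewise sits at a limit, > 100000 nM. Compound 3 therefore stands with compound 1 at the limit of > 100000 nM in this assay, at which 2 of the 3 values shown sit, set apart from compound 2 by an at least 13-fold higher number from compound 2 to compound 3 (1.13 log units; beyond the scatter). Compound 4 `COc1ccc(N2C(=O)C(c3cn(C)c4ccccc34)=C(c3nn(CCCN4CCCCC4)c4ncccc34)C2=O)cc1` differs from compound 3 by methoxy in place of chloro on an aromatic carbon. For the measured compounds named here, no measured step exchanges one substituent on that phenyl ring for another; the only step touching this nitrogen, an at least 13-fold higher number from compound 2 to compound 3 (1.13 log units; beyond the scatter), swaps the whole ring. Two of the three aryl groups examined sit at the limit, so compound 4 is expected to remain near it, with no step beyond the scatter expected: a number no higher from compound 3 to compound 4 (the limit leaves the size open). Compound 4 is estimated at 100000 nM, within 20000 nM to 400000 nM.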

Compound 4, half-maximal inhibitory concentration: 3340 nM
For compound 4 the middle estimate is 30-fold (1.48 log units) above the measured one; the whole stated range lies above it.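

In this assay the substituent on the phenyl ring alone moves the result at this nitrogen, with the ring itself unchanged (an at least 29-fold lower number from compound 3 to compound 4 (1.47 log units; beyond the scatter)). The value of compound 3 is a limit of the assay: the limit of > 100000 nM in this assay, at which 2 of the 4 values shown sit. An aryl group on this nitrogen thus does not by itself set the result, and 4-methoxyphenyl also improves on pyridin-2-yl (a 2.2-fold lower number from compound 2 to compound 4 (0.34 log units; beyond the scatter)). Open, on these data alone, is whether the gain is specific to methoxy or extends to another group in this place, such as an amine, hydroxyl or ethoxy.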